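A Trifluoromethyl Substituent Added to a Benzyloxy Urea

A few compounds are considered here, and "the series" means these few. Any claim that something is new, unique, unknown or untested is made for them only; others in the source may bear on it.

Of the compounds shown here, three built on one shared core have been measured in a functional assay on MGC-803 cells (Homo sapiens) for inhibition, read by MTT assay, with a stated time of 48 h; a lower number here means a stronger inhibitor, a higher number a weaker inhibitor. Compound 1 `Cc1ccc(NC(=S)NC(=O)c2ccc(OCc3cccc(Cl)c3)cc2)cc1-c1nc2ccccc2[nH]1` gives 51300 nM. Compound 2 `Cc1ccc(NC(=S)NC(=O)c2ccc(OCc3cccc(F)c3)cc2)cc1-c1nc2ccccc2[nH]1` gives only a limit of the assay, > 100000 nM. Compound 3 `Cc1ccc(NC(=O)NC(=O)c2ccc(OCc3ccccc3)cc2)cc1-c1nc2ccccc2[nH]1` gives 39400 nM, one of the two numbers that are not limits, the other belonging to compound 1, and the gap between the two lies within the scatter of repeated measurements.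

For the measured compounds named here, the single step that can be read from these values is an at least 1.9-fold higher number from compound 1 to compound 2 (0.28 log units; that floor lies within the scatter); its floor lies within the scatter. Compound 2 rests on (the limit of > 100000 nM in this assay, at which 1 of the 3 values shown sits).

Compound 4 `Cc1ccc(NC(=O)NC(=O)c2ccc(OCc3ccc(C(F)(F)F)cc3)cc2)cc1-c1nc2ccccc2[nH]1` differs from compound 3 in one place: trifluoromethyl in place of hydrogen on an aromatic carbon. Going by the values given here, no measured pair shows this change. Among the compounds with values here, the only measured step concerns a different exchange of halogens in the pair of compound 1 and compound 2, and its size is known only as a lower bound, so it offers no firm direction. The expectation for compound 4 is therefore a step of a 1.1-fold higher number from compound 3 to compound 4 (0.06 log units; within the scatter), taken to lie within the scatter, with a wide range on either side. Compound 4 is estimated at 45000 nM, between 15000 nM and 150000 nM.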

Compound 4, half-maximal inhibitory concentration: 14900 nM
Estimate against measurement, compound 4: 3.0-fold (0.48 log units) above; the measured number lies below the stated range.
By their numbers in this assay, from the lowest: compound 4; then compounds 3 and 1 (each within the scatter of the next). At a limit, above all of these: compound 2.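

In this assay, for the compounds shown here, placing trifluoromethyl on the aromatic carbon para to a large group, where compound 3 carries hydrogen, gives a 2.6-fold lower number from compound 3 to compound 4 (0.42 log units; beyond the scatter) and so provides the first step here that is beyond the scatter of repeated measurements. Going by these compounds alone, the earlier compounds could not show this, as none of them carries a group at this place on the ring, and the only earlier step is a halogen exchange whose size is known just as a floor. The result shows that this place is not indifferent, at least for this one pair, and that a lower number can be reached by adding a group there, but no measurement shown bears on why the number falls.

The compounds shown leave open whether the step belongs to trifluoromethyl in particular or would also appear with another group at the same place, such as a methyl, a methoxy, an amine or a carboxylic acid. They also leave open whether the same exchange would lower the number on a thiourea, since this step rests on a single pair of ureas.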